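Swapping 2-cyanoethyl for 2-cyanoethenyl on compound 2

The source may report more compounds than this note shows. Statements on the series, on what has been measured and on what is new or still open speak of the compounds shown alone.

Measured so far in a physicochemical assay for solubility, with a stated time of 4 h, at pH 2.0; on this read-out higher numbers stand for higher solubility and lower numbers for lower solubility
- compound 1 `CNC(=O)c1cc(N)c(Nc2ccc(C#N)cc2)cc1Oc1c(C)cc(CCC#N)cc1C` gives 44.7 ug/mL
- compound 2 `Cc1cc(CCC#N)cc(C)c1Oc1cc(Nc2ccc(C#N)cc2)c(N)cc1CO` gives 89.8 ug/mL

Compound 2 has no clear place above compound 1, since the two values lie within the scatter of each other (a 2.0-fold higher number from compound 1 to compound 2 (0.30 log units; within the scatter)). Compound 3 `Cc1cc(/C=C/C#N)cc(C)c1Oc1cc(Nc2ccc(C#N)cc2)c(N)cc1CO` carries 2-cyanoethenyl in place of 2-cyanoethyl on an aromatic carbon. Among the compounds with values here, the one measured step lies at a different place and stayed within the scatter, so no measured step bears directly on this change. No shift beyond the scatter is expected in this assay (a 1.3-fold lower number from compound 2 to compound 3 (0.11 log units; within the scatter)). Compound 3 is estimated at 70 ug/mL (expected range 25 ug/mL to 180 ug/mL).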

Compound 3, solubility: 20.9 ug/mL
Estimate against measurement, compound 3: 3.3-fold (0.52 log units) above; the measured number lies below the stated range.
By their numbers in this assay, from the lowest: compound 3; then compounds 1 and 2 (each within the scatter of the next).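

In this assay, within the data shown here, the aromatic carbon para to a large group proves sensitive to the chain it carries: 2-cyanoethenyl in place of 2-cyanoethyl gives a 4.3-fold lower number from compound 2 to compound 3 (0.63 log units; beyond the scatter), the only step so far beyond the scatter. The two groups differ only by the double bond. Nothing at hand accounts for this step.

From the compounds shown here alone, whether other groups at this position, such as a primary amine or a carboxylic acid, would also lower the number remains open. Also open, going by these compounds, is whether the step recurs with methylcarbamoyl in place of hydroxymethyl.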